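The source may report more compounds than this note shows. Statements on the series, on what has been measured and on what is new or still open speak of the compounds shown alone.

In a functional assay on HL-60 cells (Homo sapiens) for antiproliferative activity, read by MTT assay, with a stated time of 72 h (a lower number here means a stronger inhibitor, a higher number a weaker inhibitor), compound 1 `CN(C(=O)CCc1ccccc1)c1ccc2[nH]c(-c3n[nH]c4ccccc34)cc2n1` gives 4730 nM. Compound 2 `CN(C(=O)c1ccco1)c1ccc2[nH]c(-c3n[nH]c4ccccc34)cc2n1`, which carries a furan-2-yl in place of the phenethyl on the carbonyl carbon, gives 4540 nM. For the measured compounds named here, that change produced a 1.0-fold lower number from compound 1 to compound 2 (0.02 log units; within the scatter), so compound 2 stands level with compound 1, the only other measured compound, and neither can be told apart from the other on this assay.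

Compound 3 `Cc1ccc(S(=O)(=O)N(C)c2ccc3[nH]c(-c4n[nH]c5ccccc45)cc3n2)cc1` differs from compound 2 by (4-methylphenyl)sulfonyl in place of (furan-2-yl)carbonyl on a nitrogen on an aromatic ring. Going by the values given here, only one measured step is available to judge this, and it speaks to the change only in part: from compound 1 to compound 2 the group on the carbonyl carbon was exchanged while the carbonyl itself stayed, and the number barely moved. Among the compounds with values here, the step to compound 3 goes further, removing the carbonyl altogether and setting a sulfonyl in its place, which no measured pair covers. Within the data shown here, the one relevant step being within the scatter, the expected step is a 1.0-fold lower number from compound 2 to compound 3 (0.00 log units; within the scatter), with a broad margin for the untested exchange. Compound 3 is therefore estimated at 4500 nM, between 1500 nM and 14000 nM.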

Compound 3, half-maximal inhibitory concentration: 3030 nM
The estimate for compound 3 lay 1.5-fold (0.17 log units) above the measured number; the measured number falls inside the stated range.
By their numbers in this assay, from the lowest: compounds 3, 2 and 1 (each within the scatter of the next).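

Exchanging (furan-2-yl)carbonyl for (4-methylphenyl)sulfonyl on this nitrogen on an aromatic ring gives a 1.5-fold lower number from compound 2 to compound 3 (0.18 log units; within the scatter) in this assay and thus shows that the carbonyl itself, and not only the group it carries, can be replaced without the number leaving the scatter. Set against the phenethylcarbonyl group, the same sulfonyl gives a 1.6-fold lower number from compound 1 to compound 3 (0.19 log units; within the scatter) and so all three groups at this place stand level, although they differ in their linking unit and in their ring, a five-membered aromatic ring with a hetero atom in one case and a six-membered aromatic ring of carbon only in the others. Nothing at hand explains why this place responds so little to these exchanges.

As far as these compounds go, all three compounds carry an aromatic ring at the end of the group on this nitrogen, so it remains open whether a group without such a ring, such as a short aminoalkyl chain or a chain ending in a carboxylic acid, would stay level with them. The shared core is also the same throughout, so these compounds cannot tell whether the flat response at this nitrogen would hold on any other core.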